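Thioester series: removing the chloro group on the aromatic ring

The source may hold more compounds than are shown below. What is called first, only, known or untested is meant among the compounds shown, and "the series" means these compounds.

Measured so far:
compound 1 `O=C(S[C@]12CC[C@H](O)[C@H]1C(=O)NC2=O)c1ccccc1Cl` gives 178000 nM
compound 2 `O=C(S[C@]12CC[C@H](O)[C@H]1C(=O)NC2=O)c1ccccc1` gives 65200 nM
compound 3 `CC(=O)OC1CC[C@]2(SC(=O)c3ccccc3Cl)C(=O)NC(=O)[C@H]12` gives 101000 nM

All three were run in a functional assay on RAW264.7 cells (Mus musculus) for inhibition, read by Griess assay, with a stated time of 24 h; on this read-out higher numbers stand for weaker inhibition and lower numbers for stronger inhibition. Compound 2 differs from compound 1 by hydrogen in place of chloro on an aromatic carbon, and this change made a 2.7-fold lower number from compound 1 to compound 2 (0.44 log units; beyond the scatter). Compound 3 carries the chloro group of compound 1 on a different core; the difference between the two cores is not broken down here. Compound 3 and compound 2 lie within the scatter of each other in this assay, as do compound 3 and compound 1.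

Compound 4 `CC(=O)OC1CC[C@]2(SC(=O)c3ccccc3)C(=O)NC(=O)[C@H]12` is not yet measured. It differs from compound 3 by hydrogen in place of chloro on an aromatic carbon, with the same place description as for the change from compound 1 to compound 2, so it is the same change on the other core. For the measured compounds named here, the only step on record for this change is the one from compound 1 to compound 2, so the expectation for compound 4 in this assay rests on that single step, with the core of compound 3 as the new setting. Compound 4 is expected to give 38000 nM, roughly 15000 nM to 95000 nM, that is an expected 2.7-fold lower number from compound 3 to compound 4 (0.42 log units; beyond the scatter).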

Compound 4, half-maximal inhibitory concentration: 64300 nM
Beside the measured number, compound 4's estimate is 1.7-fold (0.23 log units) below it; the range from low to high includes it.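

In this assay, going from 2-chlorophenyl to phenyl on the second core gives a 1.6-fold lower number from compound 3 to compound 4 (0.20 log units; within the scatter), so on this core the change does not separate the pair. Set against the earlier step, the two cores cannot be told apart in their response to this change: the same change on two cores in this assay, a 2.7-fold lower number (0.44 log units; beyond the scatter) from compound 1 to compound 2 and a 1.6-fold lower number (0.20 log units; within the scatter) from compound 3 to compound 4, 1.7-fold (0.24 log units) apart, within the scatter of two such steps. This shows that the step on the core of compound 1 is compatible with the step on the second core, but it does not show that the two steps are equal, that the change has a real effect on the second core, or that any rule holds beyond these two pairs.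

The compounds shown cover only chloro and hydrogen at this aromatic carbon, so it remains open how a fluoro, methoxy or amine group there would read in this assay. From the compounds shown here alone, it also remains open whether the change would carry to a core other than these two.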